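This account rests on a few compounds, and the source may have more. Where it says the series, first, only, none or still open, it means among the compounds named here.

Compound 1 `Cc1cc(CCC#N)cc(C)c1Oc1cc(Nc2ccc(C#N)cc2)c(N)cc1C(=O)NC1CC1` gives 121000 nM in an ADME assay on TZM cells (Homo sapiens) for cytotoxicity, with a stated time of 1 days; a lower number here means that less compound is tolerated, a higher number that more compound is tolerated.
Compound 2 `Cc1cc(CCC#N)cc(C)c1Oc1cc(Nc2ccc(C#N)cc2)c(N)cc1C(=O)NC(C)C` gives 184000 nM in this assay.
Compound 3 `Cc1cc(CCC#N)cc(C)c1Oc1cc(Nc2ccc(C#N)cc2)c(N)cc1CN(C)C` gives 23800 nM in this assay.

Compound 3 stands lowest of the three in this assay: the step of a 5.1-fold lower number from compound 1 to compound 3 (0.71 log units; beyond the scatter) and the step of a 7.7-fold lower number from compound 2 to compound 3 (0.89 log units; beyond the scatter) both lie beyond the scatter, while the step of a 1.5-fold higher number from compound 1 to compound 2 (0.18 log units; within the scatter) does not. Compound 4 `Cc1cc(CCC#N)cc(C)c1Oc1ccc(N)c(Nc2ccc(C#N)cc2)c1` differs from compound 3 by hydrogen in place of (dimethylamino)methyl on an aromatic carbon. Going by the values given here, no measured step removes this group outright, so the two steps above bear on it only indirectly, both lowering the number when (dimethylamino)methyl entered. Its departure is therefore expected to move the number back upward, by a 2.5-fold higher number from compound 3 to compound 4 (0.40 log units; beyond the scatter), with wide uncertainty. Compound 4 is estimated at 60000 nM, within 20000 nM to 180000 nM.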

Compound 4, half-maximal cytotoxic concentration: > 200000 nM
Compound 4 was reported as a limit (the forecaster's own chance of this, stated with the estimate: 10%); middle value at least 3.3-fold (0.52 log units) from the limit.
By their numbers in this assay, from the lowest: compound 3; then compounds 1 and 2 (each within the scatter of the next). At a limit, above all of these: compound 4.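

In this assay compound 4 is reported only as a limit: the limit of > 200000 nM in this assay, at which 1 of the 4 values shown sits. Hydrogen in place of (dimethylamino)methyl on an aromatic carbon gives an at least 8.4-fold higher number from compound 3 to compound 4 (0.92 log units; beyond the scatter), so the low number of compound 3 goes with that group rather than with the unsubstituted position. Hydrogen in place of isopropylcarbamoyl on an aromatic carbon gives an at least 1.0-fold higher number from compound 2 to compound 4 (0.03 log units; that floor lies within the scatter), and hydrogen in place of cyclopropylcarbamoyl on an aromatic carbon gives an at least 1.6-fold higher number from compound 1 to compound 4 (0.21 log units; that floor lies within the scatter); both floors lie within the scatter, so how the two amide groups compare with hydrogen here stays unresolved. Still open, from the compounds shown here alone, is whether a primary amine or a carboxylic acid on this carbon would also lower the number, and whether a longer chain carrying the dimethylamino group would do so.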